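A Methylphenyl Variant on a Shared Core

This account rests on a few compounds, and the source may have more. Where it says the series, first, only, none or still open, it means among the compounds named here.

Two analogues share one core. Compound 1 `CCCC(=O)NC(c1ccc(N(CC)CC)cc1)c1cc(Cl)c2cccnc2c1O` and compound 2 `CCCC(=O)NC(c1ccccc1Cl)c1cc(Cl)c2cccnc2c1O` were both examined in a functional assay on Daoy cells (Homo sapiens) for antiproliferative activity, read by trypan blue exclusion and crystal violet staining, with a stated time of 72 h (a higher number here means a weaker inhibitor, a lower number a stronger inhibitor), where compound 1 gives 100 nM and compound 2 gives 100 nM; compound 2 stands level with compound 1, within the scatter. Compound 3 `CCCC(=O)NC(c1ccc(C)cc1)c1cc(Cl)c2cccnc2c1O` has not yet been measured. It differs from compound 2 in one place: 4-methylphenyl in place of 2-chlorophenyl on a saturated chain carbon bound to an amide-type nitrogen and an aromatic carbon. For the measured compounds named here, no step between measured compounds covers this change, so its size cannot be read from the data. In this assay the expected step is no change at the digits printed from compound 2 to compound 3 (within the scatter), none beyond the scatter. For compound 3 the estimate is 100 nM, with a range from 30 nM to 300 nM.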

Compound 3, half-maximal inhibitory concentration: 100 nM
Compound 3: middle estimate and measured number agree at the digits printed; low and high end bracket the measured number.
By their numbers in this assay, from the lowest: compounds 1, 2 and 3 (each within the scatter of the next).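

In this assay, the position on a saturated chain carbon bound to an amide-type nitrogen and an aromatic carbon accepts 4-methylphenyl in place of 2-chlorophenyl with no change at the digits printed from compound 2 to compound 3 (within the scatter) and no shift beyond the scatter. Methyl in place of diethylamino on an aromatic carbon likewise gives no change at the digits printed from compound 1 to compound 3 (within the scatter) in the first readable steps at this position. No available evidence bears on this result.
The compounds shown leave open whether a carboxylic acid or a primary amine on that aromatic ring would stay level with these three.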